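Capping the amine of compound 1: an estimate

The source may hold more compounds than are shown below. What is called first, only, known or untested is meant among the compounds shown, and "the series" means these compounds.

Compound 1 `Cc1nc2c(OCc3ccccc3)cccn2c1N` is the reference point. In a functional assay on the whole organism with Rattus norvegicus as the target, at a dose of 40 mg/kg by the intraperitoneal route (on this read-out higher numbers stand for more inhibition at the one dose given (going by the name of the read-out) and lower numbers for less inhibition), compound 1 gives 99%, the largest of the three numbers shown, with compound 2 inside the scatter of it and compound 3 clearly lower. Compound 2 `Cc1nc2c(OCc3ccccc3F)cccn2c1N` gives 93% in this assay, the step being a number 6 percentage points lower from compound 1 to compound 2 (within the scatter). Compound 3 `Cc1cc(OCc2ccccc2)c2nc(C)c(N)n2c1` gives 65%, the step being a number 34 percentage points lower from compound 1 to compound 3 (beyond the scatter). Compound 4 `CNC(=O)Nc1c(C)nc2c(OCc3ccccc3)cccn12` differs from compound 1 by methylcarbamoyl in place of hydrogen on a nitrogen on an aromatic ring. Among the compounds with values here, neither measured step touches this nitrogen; both concern a hydrogen on an aromatic carbon, so no measured step bears directly on the change. Within the data shown here, they show only that one small change stayed within the scatter while another change lowered the read-out by a large amount. With compound 1 at the top of the scale, an upward step is hardly possible; a drop of unknown size is the more likely outcome. The author therefore expects for compound 4 a downward step, a number 21 percentage points lower from compound 1 to compound 4 (beyond the scatter). The estimate for compound 4 is 78%, with a range from 40% to 99%.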

Compound 4, a percentage reported as inhibition, in the whole organism at one dose (the size of the read-out at that dose, not a potency): 22%
Compound 4: middle estimate off by 56 percentage points, on the high side, and the stated range ends above it.
By their numbers in this assay, from the lowest: compound 4; then compound 3; then compounds 2 and 1 (each within the scatter of the next).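

The change from amino to (methylcarbamoyl)amino is the first shown on this nitrogen, and in this assay it gives a number 77 percentage points lower from compound 1 to compound 4 (beyond the scatter). The earlier steps shown here concerned only hydrogens on aromatic carbons, whereas this one shows that the read-out at the one dose is highly sensitive to methylcarbamoyl in place of hydrogen on this nitrogen. No measurement shown here explains the fall in the read-out.

The compounds shown leave open whether this fall belongs to the methylcarbamoyl group in particular or would follow any replacement of this hydrogen, a question that a methyl, an acetyl or a longer alkyl chain on the same nitrogen would address. From the compounds shown here alone, it also remains open how the methylcarbamoyl group would behave alongside the fluoro of compound 2.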